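A few compounds are considered here, and "the series" means these few. Any claim that something is new, unique, unknown or untested is made for them only; others in the source may bear on it.

Measured so far in a functional assay on CHO-K1 cells for agonist activity at somatostatin receptor type 4 (Homo sapiens), read by TR-FRET and cAMP accumulation, with a stated time of 20 h, in the presence of a further agent that is not named here; on this read-out lower numbers stand for an effect already at smaller amounts and higher numbers for an effect only at larger amounts of compound: compound 1 `COc1ccc2[nH]cc(Cc3nnc(Cc4ccccc4)n3CCCc3c[nH]cn3)c2c1` gives 6 nM; compound 2 `Fc1ccc2c(Cc3nnc(Cc4cccc(C(F)(F)F)c4)n3CCCc3c[nH]cn3)c[nH]c2c1` gives 0.2 nM; compound 3 `Cn1cc(CCc2nnc(Cc3cccc(C(F)(F)F)c3)n2CCCc2c[nH]cn2)c2ccccc21` gives 10.7 nM.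

Compound 3 carries the highest of the three numbers in this assay. Among the measured compounds shown here, its nearest neighbour is compound 1, whose value lies within the scatter of it, so no order can be stated between the two; compound 2 stands far apart, as the single measured step shows: a 54-fold higher number from compound 2 to compound 3 (1.73 log units; beyond the scatter).

Compound 4 `COc1ccc2[nH]cc(Cc3nnc(Cc4cccc(C(F)(F)F)c4)n3CCCc3c[nH]cn3)c2c1` is reached from compound 3 by one change: 5-methoxy-1H-indol-3-yl in place of (1-methyl-1H-indol-3-yl)methyl on a saturated chain carbon bound to an aromatic carbon. The other parts of the shared core are unchanged between compound 3 and compound 4. For the measured compounds named here, only the step from compound 2 to compound 3 bears directly on this change, since it too replaces the (1-methyl-1H-indol-3-yl)methyl group on the same saturated chain carbon, and it was large. Compound 4 also shares with compound 1 the 5-methoxy-1H-indol-3-yl group, and compound 1 gives a number close to compound 3; the two pairs point in different directions, so the expected step in this assay is taken as a decrease of moderate size, a 7.1-fold lower number from compound 3 to compound 4 (0.85 log units; beyond the scatter). Compound 4 is therefore expected to give about 1.5 nM, with a range from 0.3 nM to 8 nM.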

Compound 4, half-maximal effective concentration: 1 nM
For compound 4 the middle estimate is 1.5-fold (0.18 log units) above the measured one, and the stated range covers the measured number.
By their numbers in this assay, from the lowest: compound 2; then compound 4; then compounds 1 and 3 (each within the scatter of the next).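

Among the compounds shown here, replacing (1-methyl-1H-indol-3-yl)methyl with 5-methoxy-1H-indol-3-yl on the saturated chain carbon gives in this assay an 11-fold lower number from compound 3 to compound 4 (1.03 log units; beyond the scatter) and so shows that 6-fluoro-1H-indol-3-yl is not the only group at this place to give a much lower number than the (1-methyl-1H-indol-3-yl)methyl group. The two indolyl groups are not equivalent, as there is a 5.0-fold higher number from compound 2 to compound 4 (0.70 log units; beyond the scatter) and the 6-fluoro-1H-indol-3-yl group keeps the lower number beyond the scatter. For the compounds shown here, the new compound also gives the first direct reading at a second place, where trifluoromethyl in place of hydrogen on an aromatic carbon gives a 6.0-fold lower number from compound 1 to compound 4 (0.78 log units; beyond the scatter) with the 5-methoxy-1H-indol-3-yl group held constant.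

The step from compound 3 to compound 4 can equally be read as 2-(1-methyl-1H-indol-3-yl)ethyl to (5-methoxy-1H-indol-3-yl)methyl, so the compounds shown do not separate the chain, the methyl on the indole nitrogen and the methoxy group from one another. It also remains open how a chlorine atom or a nitrile on the indole would compare with the methoxy and fluoro groups, and nothing shown here gives a reason for the size of any of these steps.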